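Selenium-bearing replacement on the methoxyphenyl arm of compound 1

The source may hold more compounds than are shown below. What is called first, only, known or untested is meant among the compounds shown, and "the series" means these compounds.

Compound 1 `COc1ccc(N(C)c2nc(C)nc3ccccc23)cc1OCCN` gives 343 nM in a functional assay on RKO cells (Homo sapiens) for inhibition, read by MTT assay, with a stated time of 48 h (a lower number here means a stronger inhibitor, a higher number a weaker inhibitor), the highest number of the three measured. Compound 3 `CN(c1ccc([Se]C#N)cc1)c1nc(C2CC2)nc2ccccc12` stands nearest with 51 nM, and compound 2 `Cc1nc(N(C)c2ccc([Se]C#N)c(F)c2)c2ccccc2n1` furthest with 8 nM; both gaps from compound 1 lie beyond the scatter, and compound 2 and compound 3 both carry a selenium-bearing group rather than the 2-aminoethoxy of compound 1.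

Compound 4 `COc1ccc(N(C)c2nc(C)nc3ccccc23)cc1[Se]C#N` is not yet measured. It differs from compound 1 at one point: a group of 3 heavy atoms (1 carbon, 1 nitrogen, 1 selenium; no ring) in place of a group of 4 heavy atoms (2 carbon, 1 nitrogen, 1 oxygen; no ring), on an aromatic carbon. Among the compounds with values here, no single-change step between measured compounds is on hand, so the size of the step rests on compound 2 and compound 3 alone.

Given that every selenium-bearing compound measured so far, compound 2 at 8 nM and compound 3 at 51 nM, returns a number well under that of compound 1, the step is expected to be a decrease beyond the scatter, an 8.6-fold lower number from compound 1 to compound 4 (0.93 log units; beyond the scatter). Compound 4 is therefore estimated at 40 nM, within 10 nM to 160 nM in this assay.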

Compound 4, half-maximal inhibitory concentration: 47 nM
The estimate for compound 4 lay 1.2-fold (0.07 log units) below the measured number, and the stated range covers the measured number.
By their numbers in this assay, from the lowest: compound 2; then compounds 4 and 3 (each within the scatter of the next); then compound 1.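

In this assay, swapping the 2-aminoethoxy for the selenium-bearing group on this aromatic carbon, ortho to a methoxy group, gives a 7.3-fold lower number from compound 1 to compound 4 (0.86 log units; beyond the scatter) on an otherwise unchanged structure. Within the data shown here, this is the first single-change step, so the lower number can be tied to this one place, whereas compound 2 and compound 3 differ from compound 1 at more than one place. It also shows that the 2-aminoethoxy, with its 1 hydrogen-bond donor, is not required at this position for a number as low as compound 4 gives at 47 nM in this series.

On these data alone, whether a simple nitrile, a longer aminoalkoxy chain or a carboxylic acid on this carbon would give a similar step remains open, as does whether the step comes from losing the 2-aminoethoxy or from gaining the selenium-bearing group. No measurement at hand gives a reason for the step.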